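From Fluoro to Bromo on the Benzyl Group

A few compounds are considered here, and "the series" means these few. Any claim that something is new, unique, unknown or untested is made for them only; others in the source may bear on it.

For the measured compounds named here, in a functional assay on A-375 cells (Homo sapiens) for antiproliferative activity, read by MTT assay, with a stated time of 24 h (on this read-out lower numbers stand for stronger inhibition and higher numbers for weaker inhibition), compound 1 (`COc1cc(OC)c(-c2coc3cc(OCC=C(C)C)ccc3c2=O)cc1OC`) gives 1580 nM and compound 2 (`COc1cc(OC)c(-c2coc3cc(OCc4ccc(F)cc4)ccc3c2=O)cc1OC`) gives 1720 nM, which places compound 2 level with the only other measured compound. Compound 3 (`COc1cc(OC)c(-c2coc3cc(OCc4ccc(Br)cc4)ccc3c2=O)cc1OC`) keeps everything in compound 2 except one atom: bromo in place of fluoro on an aromatic carbon, para to a large group. Going by the values given here, no measured pair exchanges one halogen for another, so the data hold no direct precedent. Among the compounds with values here, the one measured step, a 1.1-fold higher number from compound 1 to compound 2 (0.04 log units; within the scatter), exchanged a whole group on the same chain and stayed within the scatter, so a single halogen exchange is expected to produce no shift beyond the scatter. The estimated change in this assay is a 1.1-fold lower number from compound 2 to compound 3 (0.06 log units; within the scatter). For compound 3 the expected value is 1500 nM, with an estimated range from 750 nM to 3000 nM.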

Compound 3, half-maximal inhibitory concentration: 1000 nM
Compound 3: the middle estimate sits 1.5-fold (0.18 log units) above what was measured; the measured number falls inside the stated range.
By their numbers in this assay, from the lowest: compounds 3, 1 and 2 (each within the scatter of the next).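

In this assay, the exchange of one halogen for another at this place on the benzyl group can now be read directly: a 1.7-fold lower number from compound 2 to compound 3 (0.24 log units; within the scatter), so bromo and fluoro on this aromatic carbon, para to a large group, are not told apart here. The 4-bromobenzyl group is likewise not told apart from the chain it replaces, with a 1.6-fold lower number from compound 1 to compound 3 (0.20 log units; within the scatter), so this ether position has so far taken three different groups without a step beyond the scatter. No measurement is available that would account for these numbers.

As far as these compounds go, it remains open whether any group at this place can move the number beyond the scatter, such as an amine or a carboxylic acid on the benzyl ring. The same question stands for a longer chain on the ether oxygen.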